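Adding 4-ethylpiperazin-1-yl to compound 1

The source may hold more compounds than are shown below. What is called first, only, known or untested is meant among the compounds shown, and "the series" means these compounds.

In a functional assay on MDA-MB-231 cells (Homo sapiens) for inhibition, read by CCK-8 assay, with a stated time of 48 h (a lower number here means a stronger inhibitor of growth, a higher number a weaker inhibitor of growth), compound 1 (`Cc1ccccc1Nc1nc(Nc2ccccc2)ncc1Cl`) gives > 100000 nM, which is a limit. Compound 2 (`Cc1ccccc1Nc1nc(NCc2ccco2)ncc1Cl`) gives > 100000 nM, also a limit. For the measured compounds named here, the only measured change, a step that the two limits leave unreadable from compound 1 to compound 2, offers no size to carry forward, and the limit of > 100000 nM in this assay, at which 2 of the 2 values shown sit, is all the series shows so far. Compound 3 (`CCN1CCN(c2ccc(Nc3ncc(Cl)c(Nc4ccccc4C)n3)cc2)CC1`) differs from compound 1 at one place: 4-ethylpiperazin-1-yl in place of hydrogen on an aromatic carbon. Going by the values given here, no measured step bears on this change, so the expectation is loose. A readable step can only run toward stronger inhibition of growth in this assay because compound 1 gives > 100000 nM, a limit. The expected move is an at least 10-fold lower number from compound 1 to compound 3 (1.00 log units; beyond the scatter). Compound 3 is estimated at 10000 nM, with an expected range of 2000 nM to 60000 nM.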

Compound 3, concentration for 50% growth inhibition: 3040 nM
Estimate against measurement, compound 3: 3.3-fold (0.52 log units) above; the measured number falls inside the stated range.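

In this assay, for the compounds shown here, the series shows an at least 32-fold lower number from compound 1 to compound 3 (1.51 log units; beyond the scatter) on placing 4-ethylpiperazin-1-yl on this aromatic carbon, para to a large group, which is the first readable growth inhibition here. The size of this step is bounded by the limit of compound 1, so the true step may be larger. Compound 3 alone gives a number rather than a limit: the limit of > 100000 nM in this assay, at which 2 of the 3 values shown sit.

Whether the ethyl group is needed remains open, as an unsubstituted piperazine is not among the compounds shown. Equally open, from the compounds shown here alone, is whether a morpholine or a simple dimethylamino group on the same carbon would serve.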